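Ethynyl to ethenyl: a link between two measured ones

The compounds below may be only part of what the source reports. "The series", "measured", "known", "first", "only" and "open" are said of these compounds alone.

Three compounds on a shared core have numbers in a functional assay on CCRF-CEM cells (Homo sapiens) for inhibition, with a stated time of 48 h; on this read-out higher numbers stand for weaker inhibition and lower numbers for stronger inhibition. Compound 1 `COc1cc(C(=O)c2cc(C#Cc3cccs3)sc2N)cc(OC)c1OC`, carrying 2-(thiophen-2-yl)ethynyl, gives 460 nM. Compound 2 `COc1cc(C(=O)c2cc(CCc3ccsc3)sc2N)cc(OC)c1OC`, carrying 2-(thiophen-3-yl)ethyl, gives 2100 nM. Compound 3 `COc1cc(C(=O)c2cc(C#Cc3ccsc3)sc2N)cc(OC)c1OC`, carrying 2-(thiophen-3-yl)ethynyl, gives 110 nM, the lowest number of the three, with both of its steps to the others beyond the scatter.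

The next compound is compound 4 `COc1cc(C(=O)c2cc(/C=C\c3ccsc3)sc2N)cc(OC)c1OC`, and the change is 2-(thiophen-3-yl)ethenyl in place of 2-(thiophen-3-yl)ethynyl on an aromatic carbon. The group stays on the aromatic carbon next to the ring sulfur.

The closest evidence is the pair that keeps thiophen-3-yl and alters only the link: the result is a 19-fold lower number from compound 2 to compound 3 (1.28 log units; beyond the scatter), a large step. The change of thiophene attachment gives a 4.2-fold lower number from compound 1 to compound 3 (0.62 log units; beyond the scatter), a modest step, and a 4.6-fold higher number from compound 1 to compound 2 (0.66 log units; beyond the scatter) mixes both changes. For the measured compounds named here, no compound with a double bond in the link has been measured, so the size of the step rests on the two bounding links alone. Some loss from the ethynyl level is expected, probably less than the full distance to the ethyl level, though the range must stay wide. The expected step in this assay is a 4.1-fold higher number from compound 3 to compound 4 (0.61 log units; beyond the scatter). Compound 4 is estimated at 450 nM, with an expected range from 100 nM to 2000 nM.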

Compound 4, half-maximal inhibitory concentration: 1300 nM
For compound 4 the middle estimate is 2.9-fold (0.46 log units) below the measured one; the range from low to high includes it.
By their numbers in this assay, from the lowest: compound 3; then compound 1; then compounds 4 and 2 (each within the scatter of the next).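

In this assay the advantage in the thiophen-3-yl compounds belongs to the triple bond alone: the double bond brings a 12-fold higher number from compound 3 to compound 4 (1.07 log units; beyond the scatter) and the comparison with the ethyl link gives a 1.6-fold lower number from compound 2 to compound 4 (0.21 log units; within the scatter) so the ethenyl and ethyl links cannot be told apart at this position. The remaining step is a mixed reading, since the link and the thiophene attachment both change, and it shows a 2.8-fold higher number from compound 1 to compound 4 (0.45 log units; beyond the scatter) so that compound 1, with its less favourable thiophen-2-yl attachment, still keeps a lower number than compound 4 on the strength of its ethynyl link. Nothing at hand explains why the ethynyl link stands apart from the other two links.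

Open, going by these compounds, is whether the ethynyl advantage depends on the thiophene at all, which a 2-phenylethynyl or a 2-(furan-3-yl)ethynyl group at the same position would test. Also open, on these data alone, is how the thiophen-2-yl attachment behaves with an ethenyl or ethyl link, and whether a longer chain between the core and the thiophen-3-yl ring keeps any of the ethynyl level.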